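A few compounds are considered here, and "the series" means these few. Any claim that something is new, unique, unknown or untested is made for them only; others in the source may bear on it.

Working notes on the series. In a functional assay (strain AB) with Danio rerio as the target, read by microscopy, with a stated time of 1 h (a higher number here means that more compound is needed for the effect, a lower number that less compound is needed), compound 1 (`NC(=O)c1c(NC(=O)Nc2ccc(Cl)cc2)sc2c1CCN(CC1CCCCC1)C2`) gives 1890 nM and compound 2 (`NC(=O)c1c(NC(=O)Nc2ccc(Cl)cc2)sc2c1CCN(CC1CCCC1)C2`) gives 1830 nM so the two stand level. Among the measured compounds shown here, the one measured step, a 1.0-fold lower number from compound 1 to compound 2 (0.01 log units; within the scatter) with cyclopentyl in place of cyclohexyl, lies within the scatter.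

Compound 3 (`CC(C)(C)OC(=O)CN1CCc2c(sc(NC(=O)Nc3ccc(Cl)cc3)c2C(N)=O)C1`) is the next to read. It has tert-butoxycarbonyl in place of cyclopentyl on a saturated chain carbon bound to an amine nitrogen in a ring and the same difference can be read as cyclopentylmethyl to (tert-butoxycarbonyl)methyl.

The measured step bears on this only in part. It exchanged one carbon ring for another, whereas here the ring leaves and a group without a ring enters, carrying hydrogen-bond acceptors. The flat step from compound 1 to compound 2 therefore gives no direction for this change. A modest rise in the number is expected, on weak grounds, and no change beyond the scatter would not surprise. The expected step is a 1.5-fold higher number from compound 2 to compound 3 (0.18 log units; within the scatter) and it remains an estimate. The estimated value for compound 3 is 2800 nM with an expected range from 900 nM to 9000 nM as its bounds.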

Compound 3, half-maximal effective concentration: > 25000 nM
Compound 3: no number, only a limit; the forecaster's own chance of this, stated with the estimate: 10%; middle value at least 8.9-fold (0.95 log units) from the limit.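

Compound 3 gives no number in this assay, only a limit, so what it shows is a bound and not a size: the limit of > 25000 nM in this assay, at which 1 of the 3 values shown sits. Even so, this position is not indifferent to the group it carries: tert-butoxycarbonyl in place of cyclopentyl gives an at least 13-fold higher number from compound 2 to compound 3 (1.13 log units; beyond the scatter), and tert-butoxycarbonyl in place of cyclohexyl gives an at least 13-fold higher number from compound 1 to compound 3 (1.12 log units; beyond the scatter). Among the compounds shown here, the earlier pair showed only that one carbon ring can replace another on the saturated chain carbon bound to an amine nitrogen in a ring, with a 1.0-fold lower number from compound 1 to compound 2 (0.01 log units; within the scatter), whereas these steps show that the level held by compound 1 and compound 2 does not extend to every group placed there.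

The compounds shown leave open whether the loss of the carbon ring or the entry of the tert-butyl ester with its hydrogen-bond acceptors carries the step, since both change together in compound 3. Going by these compounds, an open alkyl chain such as neopentyl and a tetrahydropyranyl ring at this place would bear on that question, and the true value of compound 3 also stays unknown.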